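Chloro to fluoro beside the sulfonamide: expected cytotoxicity

The source may hold more compounds than are shown below. What is called first, only, known or untested is meant among the compounds shown, and "the series" means these compounds.

Compound 1, `CCS(=O)(=O)Nc1ccc(NC(=O)c2ccc(Cl)cc2)cc1Cl`, in an ADME assay on RAW264.7 cells (Mus musculus) for cytotoxicity, read by MTT assay, with a stated time of 48 h (a lower number here means a stronger inhibitor, a higher number a weaker inhibitor), gives > 250000 nM.
Compound 2, `CCS(=O)(=O)Nc1ccc(NC(=O)c2ccc(Cl)c([N+](=O)[O-])c2)cc1Cl`, in this assay gives 125000 nM.

For compound 1 the result > 250000 nM is a limit of the assay, not a number. Among the measured compounds shown here, compound 2 therefore stands as the only number in this assay among the two results. For the measured compounds named here, the single measured step, an at least 2.0-fold lower number from compound 1 to compound 2 (0.30 log units; that floor lies within the scatter), sits at a floor that falls within the scatter, and it rests on (the limit of > 250000 nM in this assay, at which 1 of the 2 values shown sits).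

Compound 3, `CCS(=O)(=O)Nc1ccc(NC(=O)c2ccc(Cl)c([N+](=O)[O-])c2)cc1F`, is not yet measured. It differs from compound 2 by fluoro in place of chloro on an aromatic carbon. Going by the values given here, no measured step bears on this change: the only one, an at least 2.0-fold lower number from compound 1 to compound 2 (0.30 log units; that floor lies within the scatter), concerns a nitro group in place of hydrogen and not the halogen. With nothing to point in either direction, the expectation for this assay is a step that stays within the scatter. Compound 3 is thus expected near 125000 nM, with a range from 40000 nM to 400000 nM. For compound 3 this means an expected step of no change at the digits printed from compound 2 to compound 3 (within the scatter), which is none beyond the scatter.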

Compound 3, half-maximal inhibitory concentration: 198000 nM
Beside the measured number, compound 3's estimate is 1.6-fold (0.20 log units) below it; measured number inside the range.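

In this assay, among the compounds shown here, fluoro in place of chloro on the aromatic carbon ortho to a (ethylsulfonyl)amino group gives a 1.6-fold higher number from compound 2 to compound 3 (0.20 log units; within the scatter), the first measured step at this position, as the earlier step concerned a nitro group at a different place. This step does not separate the two halogens, so in this pair chloro and fluoro cannot be told apart beyond the ordinary scatter of repeated measurements. Compound 2 and compound 3, which both carry the nitro group, give numbers, while the only result that is not a number belongs to compound 1, which lacks that group: the limit of > 250000 nM in this assay, at which 1 of the 3 values shown sits.

A swap between two halogens covers only a narrow range of what this position could hold, so the compounds shown say nothing about how a quite different group, such as an amine or a methoxy group, would read here. On these data alone, it also stays open whether fluoro in place of chloro would read the same way in a compound without the nitro group, where the comparison would start from a limit rather than a number.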